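Shifting a Trifluoromethyl Group: From Compound 3 to Compound 4

The source may hold more compounds than are shown below. What is called first, only, known or untested is meant among the compounds shown, and "the series" means these compounds.

Of the compounds shown here, three sharing one core have been tested in a functional assay on T47D cells (Homo sapiens) for inhibition; on this read-out lower numbers stand for stronger inhibition and higher numbers for weaker inhibition. Compound 1 `Oc1ccc(-c2cc(-c3ccc(F)cc3)cc(-c3ccccc3O)n2)cc1` gives > 50000 nM, which is a limit of the assay rather than a number. Compound 2 `Oc1ccccc1-c1cc(-c2cccc(C(F)(F)F)c2)cc(-c2ccccc2O)n1` likewise gives > 50000 nM, again only a limit. Within the data shown here, compound 3 `Oc1ccc(-c2cc(-c3ccccc3C(F)(F)F)cc(-c3ccccc3O)n2)cc1` gives 7180 nM and is therefore the only compound with a number here. As the limit of > 50000 nM in this assay, at which 2 of the 3 values shown sit, shows, the other two compounds stand at the limit. Among the measured compounds shown here, the one measured step, an at least 6.9-fold lower number from compound 1 to compound 3 (0.84 log units; beyond the scatter), shows stronger inhibition once the 2-(trifluoromethyl)phenyl group is present.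

Compound 4 `Oc1ccc(-c2cc(-c3cccc(C(F)(F)F)c3)cc(-c3ccccc3O)n2)cc1` has not been measured. It differs from compound 3 in one place: 3-(trifluoromethyl)phenyl in place of 2-(trifluoromethyl)phenyl on an aromatic carbon. For the measured compounds named here, no measured step follows exactly this move. Compound 2 carries the same 3-(trifluoromethyl)phenyl group and sits at the limit, but it differs from compound 4 elsewhere too, so it is only a hint. For compound 4 a weaker result is expected, a 3.5-fold higher number from compound 3 to compound 4 (0.54 log units; beyond the scatter). The estimate for compound 4 is 25000 nM, between 6000 nM and 60000 nM.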

Compound 4, half-maximal inhibitory concentration: > 50000 nM
Compound 4 was reported as a limit; the forecaster's own chance of this, stated with the estimate: 40%; at least 2.0-fold (0.30 log units) between middle value and limit.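

With the atoms unchanged and only their joining different, 3-(trifluoromethyl)phenyl in place of 2-(trifluoromethyl)phenyl gives an at least 6.9-fold higher number from compound 3 to compound 4 (0.84 log units; beyond the scatter) in this assay and so shows that, on this ring, where the trifluoromethyl group sits matters and not merely that it is present, which the step from compound 1 to compound 3 could not separate, since that step changed both the group and its place. For compound 4 the value > 50000 nM is a limit of the assay and not a number. Among these compounds, compound 3 thus stays the only compound with a number, while the others share one ceiling: the limit of > 50000 nM in this assay, at which 3 of the 4 values shown sit.

The steps to compound 4 from compound 1 and compound 2 cannot be read, since both ends are limits. Also open, going by these compounds, is whether a methoxy group or a chlorine in place of the trifluoromethyl group of compound 3 would keep its inhibition.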